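Isopropyl-to-bromo swap on two triazole-linked nucleoside cores

The source may hold more compounds than are shown below. What is called first, only, known or untested is meant among the compounds shown, and "the series" means these compounds.

Compound 1 `CC(C)c1ccc(-n2cc(-c3cn([C@H]4C[C@H](O)[C@@H](CO)O4)c(=O)[nH]c3=O)nn2)cc1`: in an ADME assay on CCRF-CEM cells (Homo sapiens) for cytotoxicity, read by cell counting, with a stated time of 3 days (on this read-out lower numbers stand for stronger inhibition and higher numbers for weaker inhibition), compound 1 gives 22000 nM.
Compound 2 `O=c1[nH]c(=O)n([C@H]2C[C@H](O)[C@@H](CO)O2)cc1-c1cn(-c2ccc(Br)cc2)nn1`: in this assay compound 2 gives 1800 nM.
Compound 3 `CC(C)c1ccc(-n2nncc2-c2cn([C@H]3C[C@H](O)[C@@H](CO)O3)c(=O)[nH]c2=O)cc1`: in this assay compound 3 reaches only the limit > 200000 nM, which is a limit of the assay and not a number.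

Compound 1 and compound 3 hold the same atoms joined differently; the difference between the two cores is not broken down here. On the core of compound 1 the change bromo in place of isopropyl on an aromatic carbon gave a 12-fold lower number from compound 1 to compound 2 (1.09 log units; beyond the scatter). Compound 4 `O=c1[nH]c(=O)n([C@H]2C[C@H](O)[C@@H](CO)O2)cc1-c1cnnn1-c1ccc(Br)cc1` carries the same change on the core of compound 3, (bromo in place of isopropyl on an aromatic carbon), the place being the same in both cases. Because compound 3 sits at the limit of > 200000 nM in this assay, at which 1 of the 3 values shown sits, the step to compound 4 starts from a limit, so its size cannot be fixed; from a 12-fold lower number from compound 1 to compound 2 (1.09 log units; beyond the scatter) a step of about an at least 5.0-fold lower number from compound 3 to compound 4 (0.69 log units; beyond the scatter) is expected. Compound 4 is therefore estimated at 40000 nM in this assay, expected between 10000 nM and 200000 nM, with a real chance that only a limit is reported again.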

Compound 4, half-maximal inhibitory concentration: 47000 nM
For compound 4 the middle estimate is 1.2-fold (0.07 log units) below the measured one; the measured number falls inside the stated range.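

In this assay, bromo in place of isopropyl again goes with a lower number, an at least 4.2-fold lower number from compound 3 to compound 4 (0.62 log units; beyond the scatter), so the direction seen on the core of compound 1 also appears on the core of compound 3. Set side by side, the two steps compare only loosely: the same change on two cores in this assay, a 12-fold lower number (1.09 log units; beyond the scatter) from compound 1 to compound 2 and an at least 4.2-fold lower number (0.62 log units; beyond the scatter) from compound 3 to compound 4; the limit leaves it open whether they differ
For compound 3 the reading of > 200000 nM is a limit of the assay and not a number, so the result shows a shared direction on these two cores but gives neither a fixed size for this step nor any sign that the change would carry equally to a further core.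

The compounds shown leave open whether another group in the place of the bromo, such as chloro, a methoxy group, an amine or a carboxylic acid, would follow the same direction on both cores. They also leave open whether the step seen in these cells would appear in any other cell type.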